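One methyl fewer on compound 2

A few compounds are considered here, and "the series" means these few. Any claim that something is new, unique, unknown or untested is made for them only; others in the source may bear on it.

Compound 1 `CC/C=C\C/C=C\C/C=C\CCCCCCCc1cc(=O)c2c(O)cc(O)cc2o1`: 17500 nM
Compound 2 `CC/C=C\C/C=C\C/C=C\CCCCCCCc1cc(=O)c2c(O)c(C)c(O)c(C)c2o1`: 17500 nM
Compound 3 `CCCC/C=C\CCCCCCCCCc1cc(=O)c2c(O)c(C)c(O)c(C)c2o1`: > 67200 nM (a limit)

In a functional assay on MCF7 cells (Homo sapiens) for antiproliferative activity, read by MTT assay (on this read-out lower numbers stand for stronger inhibition and higher numbers for weaker inhibition), compound 2 gives 17500 nM and stands level with compound 1 at 17500 nM. Compound 3 gives > 67200 nM, which is a limit of the assay and not a number. Within the data shown here, the only measured step, an at least 3.8-fold higher number from compound 2 to compound 3 (0.58 log units; beyond the scatter), changes the chain and leaves the methyl groups on the shared core as they are, so it offers little guidance here.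

The next structure is compound 4 `CC/C=C\C/C=C\C/C=C\CCCCCCCc1cc(=O)c2c(O)c(C)c(O)cc2o1`, which keeps the chain of compound 2. The change is hydrogen in place of methyl on an aromatic carbon. Among the measured compounds shown here, no measured step isolates this methyl. Compound 1 also has hydrogen on that carbon, and compound 1 gives 17500 nM. On that basis, no step beyond the scatter is expected in this assay, and the estimated change is no change at the digits printed from compound 2 to compound 4 (within the scatter). For compound 4 the estimated value is 17500 nM, with an expected range from 8000 nM to 38000 nM.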

Compound 4, half-maximal inhibitory concentration: 17500 nM
Compound 4: the middle estimate sits on the measured number at the digits printed, within the range that was stated.
By their numbers in this assay, from the lowest: compounds 1, 2 and 4 (each within the scatter of the next). At a limit, above all of these: compound 3.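

With the chain of compound 2 kept, hydrogen in place of methyl on the aromatic carbon para to a hydroxy group gives no change at the digits printed from compound 2 to compound 4 (within the scatter) in this assay. Methyl in place of hydrogen on an aromatic carbon of the shared core likewise gives no change at the digits printed from compound 1 to compound 4 (within the scatter), so each methyl has now been read on its own, where the earlier compounds on this chain carried either both methyls or neither. No measurement shown here accounts for these level values.

On these data alone, it remains open whether a larger or differently built group on this carbon, such as an ethyl group, a methoxy group, an amine or a carboxylic acid, would shift the number. Also open, as far as these compounds go, is whether these methyl changes would read the same on a different chain.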